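A few compounds are considered here, and "the series" means these few. Any claim that something is new, unique, unknown or untested is made for them only; others in the source may bear on it.

Measured compounds:
Compound 1 `CCOC(=O)C12C(=O)OCC=C1COC2c1ccc(OC)c(OC)c1`: > 1000000 nM
Compound 2 `CCOC(=O)C12C(=O)OCC=C1COC2c1cc(OC)cc(OC)c1`: > 1000000 nM

In a functional assay on A549 cells (Homo sapiens) for cytotoxicity, read by MTT assay (on this read-out higher numbers stand for weaker inhibition and lower numbers for stronger inhibition), compound 1 gives > 1000000 nM, which is a limit of the assay rather than a number. In this assay compound 2 likewise gives > 1000000 nM, again a limit and not a measured value. Compound 2 therefore stands at the edge of what this assay can report, and it does not stand alone there, since (the limit of > 1000000 nM in this assay, at which 2 of the 2 values shown sit). For the measured compounds named here, no step between measured compounds can be drawn from these two readings; all that the pair shows is that neither compound reached a measurable concentration.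

Compound 3 `CCOC(=O)C12C(=O)OCC=C1COC2c1cc(OC)c(OC)c(OC)c1` has not yet been measured in this assay. It differs from compound 2 by methoxy in place of hydrogen on an aromatic carbon. Going by the values given here, with both known compounds sitting at the limit, there is no measured step on which to base a direction, and no change beyond the scatter is expected from compound 2 to compound 3, with the step estimated as a step that the limit leaves unreadable from compound 2 to compound 3. For compound 3 the expected value in this assay is 1500000 nM, with a range from 300000 nM to 5000000 nM, and a limit reading is considered the most likely outcome.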

Compound 3, half-maximal inhibitory concentration: 13300 nM
The estimate for compound 3 lay 110-fold (2.05 log units) above the measured number, outside the stated range (below it).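

For the compounds shown here, this aromatic carbon, ortho to two methoxy groups and para to a large group, is the first place where a change brings the reading off the limit: in this assay, methoxy in place of hydrogen there gives an at least 75-fold lower number from compound 2 to compound 3 (1.87 log units; beyond the scatter). Reached from the other dimethoxy arrangement, the third methoxy on the ring gives an at least 75-fold lower number from compound 1 to compound 3 (1.87 log units; beyond the scatter), so neither arrangement of two methoxy groups shown gave a measurable reading, while the compound with three did. Both steps are bounds rather than full sizes, and their true extent cannot be read: the limit of > 1000000 nM in this assay, at which 2 of the 3 values shown sit.

The compounds shown do not tell whether the methoxy itself is what counts at this carbon, or whether a hydroxyl, an amine or a longer ether such as ethoxy would give a similar reading there. They also give no account of why the third methoxy has this effect, and they do not show whether it would appear in any cells other than those of this one read-out.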